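The source may hold more compounds than are shown below. What is called first, only, known or untested is meant among the compounds shown, and "the series" means these compounds.

Compound 1 `CS(=O)(=O)NC1CCC(CN2CCN(c3cc(=O)c4cc(C(F)(F)F)cc([N+](=O)[O-])c4s3)CC2)CC1` carries a methanesulfonamido group on a saturated ring carbon of its core. In an ADME assay on cells (Hepatocyte, Homo sapiens) for metabolic stability (on this read-out lower numbers stand for a shorter-lived compound and higher numbers for a longer-lived compound), compound 1 gives > 1.55 h, which is a limit of the assay and not a number (the limit of > 1.55 h in this assay, at which 1 of the 2 values shown sits). Compound 2 `O=C(OC1CCC(CN2CCN(c3cc(=O)c4cc(C(F)(F)F)cc([N+](=O)[O-])c4s3)CC2)CC1)c1ccco1` carries a ((furan-2-yl)carbonyl)oxy group in that position instead, and in this assay compound 2 gives 0.075 h; the measured step is an at least 20-fold lower number from compound 1 to compound 2 (1.31 log units; beyond the scatter). Compound 3 `COc1ccc(C(=O)OC2CCC(CN3CCN(c4cc(=O)c5cc(C(F)(F)F)cc([N+](=O)[O-])c5s4)CC3)CC2)cc1` has not yet been measured; compared with compound 1 the change is ((4-methoxyphenyl)carbonyl)oxy in place of methanesulfonamido on a saturated ring carbon. Among the compounds with values here, the only measured step that bears on this change is the one from compound 1 to compound 2, which likewise exchanged the methanesulfonamido group for an ester on the same saturated ring carbon and was large. A step of the same direction and of comparable size is therefore expected for compound 3 in this assay, namely an at least 10-fold lower number from compound 1 to compound 3 (1.01 log units; beyond the scatter). For compound 3 the estimate in this assay is 0.15 h, with a range from 0.04 h to 0.6 h.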

Compound 3, half-life: 0.165 h
For compound 3 the middle estimate is 1.1-fold (0.04 log units) below the measured one, within the range that was stated.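

In this assay, a second ester on the saturated ring carbon also gives a much lower number than the methanesulfonamido group, with an at least 9.3-fold lower number from compound 1 to compound 3 (0.97 log units; beyond the scatter), so the drop is not confined to the furan-2-yl ester of compound 2. The group on the ester carbonyl also counts, though less: 4-methoxyphenyl in place of furan-2-yl gives a 2.2-fold higher number from compound 2 to compound 3 (0.34 log units; beyond the scatter). Compound 1 remains a limit of the assay and not a number, so the full size of its step to either ester stays unknown: the limit of > 1.55 h in this assay, at which 1 of the 3 values shown sits.

The compounds shown leave open how an amide carrying the same 4-methoxyphenyl carbonyl, or a plain hydroxyl group, would compare on that ring carbon. They also leave open whether a fluorine or a nitrile on the aromatic ring of the ester would shift the number.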